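Swapping trifluoromethyl for trifluoromethoxy on a second core

The source may hold more compounds than are shown below. What is called first, only, known or untested is meant among the compounds shown, and "the series" means these compounds.

Compound 1 `CC(O)(CSc1ccccc1C(F)(F)F)C(=O)Nc1ccc(S(F)(F)(F)(F)F)cc1` and compound 2 `CC(O)(CSc1ccccc1OC(F)(F)F)C(=O)Nc1ccc(S(F)(F)(F)(F)F)cc1` share one core, while compound 3 `CC(O)(COc1ccc(C(F)(F)F)cc1)C(=O)Nc1cccc(S(F)(F)(F)(F)F)c1` and compound 4 `CC(O)(COc1ccc(OC(F)(F)F)cc1)C(=O)Nc1cccc(S(F)(F)(F)(F)F)c1` share another; the difference between the two cores is not broken down here. In a functional assay on VCaP cells (Homo sapiens) for antiproliferative activity, read by propidium iodide staining, with a stated time of 96 h (a lower number here means a stronger inhibitor, a higher number a weaker inhibitor), compound 1 gives 21000 nM and compound 2 gives 10100 nM. The change between them, (trifluoromethoxy in place of trifluoromethyl on an aromatic carbon), made the step of a 2.1-fold lower number from compound 1 to compound 2 (0.32 log units; beyond the scatter). In this assay compound 3 gives 13300 nM. Compound 4 is not yet measured; it differs from compound 3 by trifluoromethoxy in place of trifluoromethyl on an aromatic carbon. For the measured compounds named here, this is the same kind of change as the one from compound 1 to compound 2, not the same one: in the first pair the group sits ortho to a large group, in the second para to a large group, and the cores differ. Because the earlier step was a 2.1-fold lower number from compound 1 to compound 2 (0.32 log units; beyond the scatter), for compound 4 a step of similar size is expected, a 1.7-fold lower number from compound 3 to compound 4 (0.22 log units; within the scatter), with the different core adding uncertainty. Compound 4 is therefore estimated at 8000 nM, with a likely range from 4000 nM to 16000 nM.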

Compound 4, half-maximal inhibitory concentration: 20200 nM
Compound 4: middle estimate off by 2.5-fold (0.40 log units), on the low side; measured number outside the range, above it.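

In this assay, trifluoromethoxy in place of trifluoromethyl on the second core gives a 1.5-fold higher number from compound 3 to compound 4 (0.18 log units; within the scatter), so on this core the swap makes no difference that can be told apart from ordinary measurement scatter. Set beside the earlier step, the same swap does not carry over from one core to the other at the same size: the same change on two cores in this assay, a 2.1-fold lower number (0.32 log units; beyond the scatter) from compound 1 to compound 2 and a 1.5-fold higher number (0.18 log units; within the scatter) from compound 3 to compound 4, 3.2-fold (0.50 log units) apart, beyond the scatter of two such steps. This shows that, in this series, a step read on one core was a poor guide to the step on another, but it does not show what lies behind the gap, as the two pairs differ both in the core and in where the group sits on the ring.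

The compounds shown leave open whether the gap follows the core or the position, which would take the same swap at the same place on both cores. They also leave open how another group at this place, such as a nitrile or an amine, would compare with trifluoromethyl and trifluoromethoxy.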